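The source may hold more compounds than are shown below. What is called first, only, known or untested is meant among the compounds shown, and "the series" means these compounds.

Working notes on the series.

The series is built on a shared core carrying a primary carboxamide, an acylated amino group on the thiophene, and a substituted nitrogen in the saturated ring. Compound 1 `NC(=O)c1c(NC(=O)c2ccccc2Cl)sc2c1CCN(Cc1ccccc1)C2` is the reference for the step followed here. In a functional assay on HeLa cells (Homo sapiens) for antiproliferative activity, with a stated time of 24 h (on this read-out lower numbers stand for stronger inhibition and higher numbers for weaker inhibition), compound 1 gives 38400 nM. Within the data shown here, the only other measured member is compound 2 `NC(=O)c1c(NC(=O)c2cccc([N+](=O)[O-])c2)sc2c1CCN(Cc1c(Cl)cccc1Cl)C2`, which differs in two places at once; in this assay compound 2 gives 46100 nM, and the gap between the two values lies within the usual scatter, so the pair shows no difference beyond noise and no pattern can be drawn from it.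

The step in question leads to compound 3 `NC(=O)c1c(NC(=O)c2ccccc2Cl)sc2c1CCN(C(=O)Nc1ccccc1Cl)C2`. The change is (2-chlorophenyl)carbamoyl in place of benzyl on an amine nitrogen in a ring. Among the measured compounds shown here, no comparable change is available among measured compounds, so nothing indicates its direction; the single measured pair only shows that the two substitution patterns seen so far sit in the same range. The working expectation is therefore a step of no more than the scatter, in either direction, expressed as a 1.0-fold lower number from compound 1 to compound 3 (0.00 log units; within the scatter). On that basis compound 3 is estimated at 38000 nM in this assay, with a range from 12000 nM to 120000 nM.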

Compound 3, half-maximal inhibitory concentration: 45400 nM
Beside the measured number, compound 3's estimate is 1.2-fold (0.08 log units) below it; measured number inside the range.
By their numbers in this assay, from the lowest: compounds 1, 3 and 2 (each within the scatter of the next).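

Among these compounds, the first one-place comparison, read in this assay, gives a 1.2-fold higher number from compound 1 to compound 3 (0.07 log units; within the scatter), so benzyl and (2-chlorophenyl)carbamoyl cannot be told apart at this amine nitrogen in a ring. The exchange is not a small one on paper: the entering group is larger by the heavy-atom count and brings a double bond outside aromatic rings, a hydrogen-bond donor and a hydrogen-bond acceptor that benzyl lacks, yet the number shows no difference beyond the scatter in this one pair. No supporting measurement bears on why this change leaves the read-out unmoved.

Going by these compounds, what stays open is whether any group on this ring nitrogen can move the number beyond the scatter, for instance a carboxylic acid on a longer chain, a simple alkyl chain, or an unsubstituted ring nitrogen carrying only hydrogen. On these data alone, it is also open whether the same exchange gives the same step when the 2-chlorobenzoyl-type acyl group on the thiophene amino is replaced by another one, such as a plain acetyl.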